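Trifluoromethyl for Cyano on a Urate Transporter Inhibitor Core

The source may hold more compounds than are shown below. What is called first, only, known or untested is meant among the compounds shown, and "the series" means these compounds.

Compound 1 `N#Cc1cc(C(=O)N2CS(=O)(=O)c3ccccc32)cc(C2CC2)c1O`: 19200 nM
Compound 2 `N#Cc1cc(C(=O)N2CS(=O)(=O)c3ccccc32)cc(C(F)(F)F)c1O`: > 100000 nM
Compound 3 `N#Cc1cc(C(=O)N2CS(=O)(=O)c3ccccc32)cc(Cl)c1O`: > 100000 nM

In an assay on tissue (RPTEC cells) for inhibition of solute carrier family 22 member 12 (Homo sapiens), read by scintillation counting, with stated times of 15 min and 2 h (on this read-out lower numbers stand for stronger inhibition and higher numbers for weaker inhibition), compound 1 gives 19200 nM. For compound 2 the value > 100000 nM is a limit of the assay, not a number. For compound 3 the value > 100000 nM is likewise a limit. Compound 3 therefore stands at the weak end of what the assay can report, a position it shares with one other compound here, as the limit of > 100000 nM in this assay, at which 2 of the 3 values shown sit, shows.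

Compound 4 `O=C(c1cc(Cl)c(O)c(C(F)(F)F)c1)N1CS(=O)(=O)c2ccccc21` arises from compound 3 by trifluoromethyl in place of cyano on an aromatic carbon. Going by the values given here, none of the measured steps changes this cyano group: an at least 5.2-fold higher number from compound 1 to compound 2 (0.71 log units; beyond the scatter) and an at least 5.2-fold higher number from compound 1 to compound 3 (0.71 log units; beyond the scatter) both change the group on the other side of the hydroxy, and a step that the two limits leave unreadable from compound 2 to compound 3 cannot be read. So the change to compound 4 is untested, and the starting point is already a limit.

Compound 4 is expected to stay at or beyond that limit, with a step that the limit leaves unreadable from compound 3 to compound 4 as the estimated step, and its estimated value is 150000 nM, within a range from 50000 nM to 500000 nM.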

Compound 4, half-maximal inhibitory concentration: 2600 nM
For compound 4 the middle estimate is 58-fold (1.76 log units) above the measured one, outside the stated range (below it).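

In this assay the place held by the nitrile turns out to be one where a swap brings back measurable inhibition: trifluoromethyl in its place gives an at least 38-fold lower number from compound 3 to compound 4 (1.58 log units; beyond the scatter) and chloro in its place gives an at least 38-fold lower number from compound 2 to compound 4 (1.58 log units; beyond the scatter) on the shared core. Going by these compounds alone, the earlier steps had changed only the other group on the ring, so this is the first sign that the nitrile's place also shapes the read-out. Each of these steps is a minimum, since each starts from a limit of the assay, and the step from compound 2 to compound 3 still cannot be read: the limit of > 100000 nM in this assay, at which 2 of the 4 values shown sit.

Going by these compounds, whether the gain belongs to losing the nitrile or to the pairing of chloro with trifluoromethyl stays open. On these data alone, how a carboxylic acid or an amine would read in the nitrile's place is also open.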